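The source may hold more compounds than are shown below. What is called first, only, known or untested is meant among the compounds shown, and "the series" means these compounds.

Three compounds have numbers in an assay on isolated protein for binding affinity to histamine H2 receptor (Homo sapiens) (a lower number here means a stronger inhibitor, a higher number a weaker inhibitor), so far. Compound 1 `CC(=O)c1ccc(OCCCN2CC[C@H](NS(=O)(=O)c3ccc(C#N)cc3)C2)cc1`, which carries a 4-cyanophenyl on its sulfonyl sulfur, gives in this assay 2300 nM. Compound 2 `O=C(c1ccc(OCCCN2CC[C@H](NS(=O)(=O)c3ccc(Br)cc3)C2)cc1)C1CC1`, with a 4-bromophenyl on the sulfonyl sulfur and a cyclopropyl ketone on the core, gives in this assay 290 nM. Compound 3 `O=C(N[C@H]1CCN(CCCOc2ccc(C(=O)C3CC3)cc2)C1)c1csc(-c2cccnc2)n1`, in which the sulfonamide is replaced by a thiazole carboxamide, gives in this assay 4000 nM. Compound 2 therefore holds the lowest number of the three, and both gaps, to compound 1 and to compound 3, lie beyond the scatter of this assay, so compound 2 is the strongest binder among the measured set.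

Compound 4 `Cc1ccccc1S(=O)(=O)N[C@H]1CCN(CCCOc2ccc(C(=O)C3CC3)cc2)C1` has not been measured. It differs from compound 2 in one place: 2-methylphenyl in place of 4-bromophenyl on a sulfonyl sulfur. Going by the values given here, no pair of measured compounds differs by this change alone, so the size of its effect is not known from the data. The account expects the step from compound 2 to compound 4 to raise the number, in the direction of weaker binding, by an amount estimated at a 3.4-fold higher number from compound 2 to compound 4 (0.54 log units; beyond the scatter). On that basis compound 4 is expected to give in this assay about 1000 nM, with a range from 300 nM to 4000 nM.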

Compound 4, inhibition constant: 2200 nM
Compound 4: the middle estimate sits 2.2-fold (0.34 log units) below what was measured, within the range that was stated.
By their numbers in this assay, from the lowest: compound 2; then compounds 4, 1 and 3 (each within the scatter of the next).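

In this assay, going by these compounds alone, the swap of 4-bromophenyl for 2-methylphenyl on a sulfonyl sulfur gives a 7.6-fold higher number from compound 2 to compound 4 (0.88 log units; beyond the scatter) and is the first comparison in the set that changes one place alone. Compounds 1, 2 and 3 differ from one another in more than one place, so they could not show that this group alone, with the rest of the molecule kept, moves the number beyond the scatter. The two groups match in heavy-atom count and in their zero counts of hydrogen-bond donors and acceptors, so these counts do not tell them apart, and nothing measured here explains the step.

Still open, on these data alone, is whether 4-methylphenyl or 2-bromophenyl on the same sulfur would give a number closer to that of compound 2 or that of compound 4, which would separate the exchange of bromine for methyl from the different placing of the group on the ring. Also open, as far as these compounds go, is whether the same step would hold on the core of compound 1, which has a methyl ketone where compound 2 and compound 4 have a cyclopropyl ketone.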